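Replacing an Isopropoxy Group with Phenyl: Expected Potency Change

The source may hold more compounds than are shown below. What is called first, only, known or untested is meant among the compounds shown, and "the series" means these compounds.

Measured compounds:
Compound 1 `CCCCc1ccc(-c2c(C)[nH]c(=O)n2CCCC)cc1` gives 12000 nM in a functional assay on brain (Rattus norvegicus, strain Wistar) for inhibition; a lower number here means a stronger inhibitor, a higher number a weaker inhibitor.
Compound 2 `Cc1[nH]c(=O)n(C)c1-c1ccc(OC(C)C)cc1` gives 20400 nM in this assay.
Compound 3 `CCCCCCCOc1ccc(-c2c(C)[nH]c(=O)n2C)cc1` gives 5700 nM in this assay.

Compound 2 has the highest number of the three, so it is the weakest inhibitor shown; compound 1 is within the scatter of it, while compound 3 lies beyond it. Compound 4 `Cc1[nH]c(=O)n(C)c1-c1ccc(-c2ccccc2)cc1` differs from compound 2 in one place: phenyl in place of isopropoxy on an aromatic carbon. Among the measured compounds shown here, only one measured step touches the same position: a 3.6-fold lower number from compound 2 to compound 3 (0.55 log units; beyond the scatter), where a longer chain on the oxygen gave a modestly lower number. Phenyl is another larger group at that position, so a step of similar direction and size is expected. For compound 4 the estimate is 8000 nM, with a likely range of 3000 nM to 22000 nM, meaning an expected step of a 2.6-fold lower number from compound 2 to compound 4 (0.41 log units; beyond the scatter).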

Compound 4, half-maximal inhibitory concentration: 6300 nM
For compound 4 the middle estimate is 1.3-fold (0.10 log units) above the measured one; the range from low to high includes it.
By their numbers in this assay, from the lowest: compounds 3, 4, 1 and 2 (each within the scatter of the next, the first and the last beyond it).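

Swapping isopropoxy for phenyl gives a 3.2-fold lower number from compound 2 to compound 4 (0.51 log units; beyond the scatter) in this assay. The earlier step, a 3.6-fold lower number from compound 2 to compound 3 (0.55 log units; beyond the scatter), kept the oxygen on the aromatic ring and changed only the chain on it, whereas compound 4 has no oxygen there, so a lower number at this position does not depend on that oxygen. No measurement shown explains this step.

Still open, from the compounds shown here alone, is how phenoxy, which carries both the oxygen and a phenyl ring, or cyclohexyl, a non-aromatic ring, would fare at this position.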